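This account rests on a few compounds, and the source may have more. Where it says the series, first, only, none or still open, it means among the compounds named here.

Measured so far:
Compound 1, `COc1cc(OC)c2sc(-c3ccc(N/C=C\C(=O)c4ccc(OC)c([N+](=O)[O-])c4)c(C)c3)nc2c1`, gives 12100 nM.
Compound 2, `COc1ccc(C(=O)/C=C\Nc2ccc(-c3nc4cc(OC)c(OC)c(OC)c4s3)cc2C)cc1[N+](=O)[O-]`, gives 9100 nM.
Compound 3, `COc1cc(OC)c2sc(-c3ccc(N/C=C\C(=O)c4ccc(OC)c([N+](=O)[O-])c4)cc3)nc2c1`, gives 5800 nM.

These three numbers come from a functional assay on A549 cells (Homo sapiens) for antiproliferative activity, read by sulforhodamine B assay, with a stated time of 48 h; on this read-out higher numbers stand for weaker inhibition and lower numbers for stronger inhibition. On this read-out compound 1 stands highest of the three, meaning the weakest inhibition shown: compound 2 sits nearest, with a 1.3-fold lower number from compound 1 to compound 2 (0.12 log units; within the scatter), and compound 3 furthest, with a 2.1-fold lower number from compound 1 to compound 3 (0.32 log units; beyond the scatter).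

Compound 4, `COc1cc(OC)c2sc(-c3ccc(N/C=C\C(=O)c4cc(OC)c(OC)c(OC)c4)c(C)c3)nc2c1`, has not yet been measured. It differs from compound 1 in one place: 3,4,5-trimethoxyphenyl in place of 4-methoxy-3-nitrophenyl on a carbonyl carbon. Both measured steps touch other parts of the molecule, one adding a methoxy to the shared core and the other swapping a methyl for hydrogen on the aromatic ring next in the chain, so neither bears directly on the exchange of the ring on the carbonyl carbon. For the measured compounds named here, the data give no precedent for this change, and the expectation must stay loose. Taking compound 1 as the starting point, the step to compound 4 is expected to be a 2.4-fold lower number from compound 1 to compound 4 (0.38 log units; beyond the scatter). For compound 4 the estimate in this assay is 5000 nM, with a range from 800 nM to 30000 nM.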

Compound 4, half-maximal inhibitory concentration: 14400 nM
Beside the measured number, compound 4's estimate is 2.9-fold (0.46 log units) below it, within the range that was stated.
By their numbers in this assay, from the lowest: compounds 3, 2, 1 and 4 (each within the scatter of the next, the first and the last beyond it).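

For the compounds shown here, this is the first look at the ring on the carbonyl carbon, since the earlier steps changed other parts of the molecule. In this assay the exchange of 4-methoxy-3-nitrophenyl for 3,4,5-trimethoxyphenyl gives a 1.2-fold higher number from compound 1 to compound 4 (0.08 log units; within the scatter) and so leaves the two compounds indistinguishable on this read-out, even though the entering ring has three methoxy groups and no nitrogen, while the leaving ring has one methoxy group and a nitro group. For this pair, then, these two quite different rings on the carbonyl carbon read alike, but no measurement shown here explains why.

One pair on one version of the shared core cannot show whether the exchange would read the same way on the core of compound 2 or compound 3, so the result should not yet be taken as a general rule for this position. From the compounds shown here alone, it also remains open how the number would respond to a ring on the carbonyl carbon that carries an amine or a carboxylic acid, or to a simple unsubstituted phenyl ring there.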